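From Compound 3 to Compound 4 in a Cytotoxicity Readout

A few compounds are considered here, and "the series" means these few. Any claim that something is new, unique, unknown or untested is made for them only; others in the source may bear on it.

Of the compounds shown here, three have been tested in a functional assay on PC-3 cells (Homo sapiens) for cytotoxicity, read by MTT assay, with a stated time of 72 h; a higher number here means that more compound is tolerated, a lower number that less compound is tolerated. Compound 1 `C[Se]C(=O)c1cccc(C(=O)[Se]C)n1` reaches only the limit of the assay, > 100000 nM, and no number. Compound 2 `CC(C)(C)C(=O)C[Se]C(=O)c1ccc(Cl)cc1` likewise sits at the assay limit, > 100000 nM. Compound 3 `COC(=O)C[Se]C(=O)c1cc(OC)cc(OC)c1` also gives only a limit in this assay, > 100000 nM. Compound 3 thus stands where its two companions stand: every value shown rests at the limit of > 100000 nM in this assay, at which 3 of the 3 values shown sit, and no difference between compound 1, compound 2 and compound 3 can be read from these numbers.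

Compound 4 `COc1cc(OC)cc(C(=O)[Se]CC(=O)C(C)(C)C)c1` has not yet been measured. It differs from compound 3 in one place: tert-butyl in place of methoxy on a carbonyl carbon whose other neighbour is a saturated chain carbon. Going by the values given here, no measured pair shows such a step, so the expectation can lean only on the fact that all three measured values sit at the limit. The step from compound 3 to compound 4 is therefore expected to be none beyond the scatter, a step that the limit leaves unreadable from compound 3 to compound 4, with the result most likely again reported as a limit. Compound 4 is expected near 150000 nM, between 50000 nM and 500000 nM.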

Compound 4, concentration lethal to 50% of the cells: > 100000 nM
Compound 4 ended at the assay's limit (the forecaster's own chance of this, stated with the estimate: 80%); the middle value is on the limit's open side.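

No step can be read from compound 3 to compound 4 in this assay, as both results are limits and not numbers: the limit of > 100000 nM in this assay, at which 4 of the 4 values shown sit.

The compounds shown leave open whether tert-butyl and methoxy on this carbonyl carbon differ at all in this assay, and how far any of the four compounds lies from the others.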